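A new aryl group on the amide of compound 3

A few compounds are considered here, and "the series" means these few. Any claim that something is new, unique, unknown or untested is made for them only; others in the source may bear on it.

Values in an ADME assay on MT4 cells (Homo sapiens) for cytotoxicity, read by MTT assay, with a stated time of 5 days (on this read-out higher numbers stand for lower toxicity in this test and lower numbers for higher toxicity in this test), so far:
compound 1 `COc1cc2nc(Nc3ccc(C#N)cc3)nc(Nc3c(F)cc(/C=C/C#N)cc3F)c2cc1OC` gives 6400 nM
compound 2 `COc1cc2nc([S+]([O-])CC(=O)Nc3cccc(Cl)c3)nc(Nc3c(Cl)cc(/C=C/C#N)cc3Cl)c2cc1OC` gives 68900 nM
compound 3 `COc1cc2nc([S+]([O-])CC(=O)Nc3ccccc3C(F)(F)F)nc(Nc3c(Cl)cc(/C=C/C#N)cc3Cl)c2cc1OC` gives > 192000 nM (a limit, not a number)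

Compound 3 stands at the limit of > 192000 nM in this assay, at which 1 of the 3 values shown sits, and so has no exact place on the scale. Compound 4 `COc1cc2nc([S+]([O-])CC(=O)Nc3cc([N+](=O)[O-])ccc3F)nc(Nc3c(Cl)cc(/C=C/C#N)cc3Cl)c2cc1OC` carries 2-fluoro-5-nitrophenyl in place of 2-(trifluoromethyl)phenyl on an amide-type nitrogen. For the measured compounds named here, one measured step bears on this site: an at least 2.7-fold higher number from compound 2 to compound 3 (0.44 log units; beyond the scatter), with 2-(trifluoromethyl)phenyl in place of 3-chlorophenyl. Compound 2 at 68900 nM shows that another aryl group on this nitrogen can give a measurable number in this assay, so a lower number is expected for the new group, of about the size of that measured step or somewhat more. The expected change is an at least 2.7-fold lower number from compound 3 to compound 4 (0.43 log units; beyond the scatter), and its estimated size remains loose. For compound 4 the estimate is 70000 nM, with an expected range of 20000 nM to 190000 nM.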

Compound 4, half-maximal cytotoxic concentration: > 194000 nM
Compound 4 gave a limit, no number (the forecaster's own chance of this, stated with the estimate: 25%); at least 2.7-fold (0.44 log units) between middle value and limit.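

In this assay compound 4 gives a limit and not a number: the limit of > 194000 nM in this assay, at which 1 of the 4 values shown sits. Putting 2-fluoro-5-nitrophenyl in place of 3-chlorophenyl on the amide-type nitrogen gives an at least 2.8-fold higher number from compound 2 to compound 4 (0.44 log units; beyond the scatter), so a second, differently substituted aryl group now stands on the same side of compound 2 as the 2-(trifluoromethyl)phenyl of compound 3, and the higher number is not tied to the trifluoromethyl group alone. The step from compound 3 to compound 4 cannot be read, since each end of it is a limit.

Among the three aryl amides, only compound 2, at 68900 nM, has an exact place on the scale, so the true distance between these groups stays open. Also open, going by these compounds, is how this assay would read with a straight alkyl chain on this nitrogen, or with a phenyl ring carrying an amine or a carboxylic acid.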